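Replacing 2-bromo-6-chlorophenyl with 3-methylphenyl: working notes

A few compounds are considered here, and "the series" means these few. Any claim that something is new, unique, unknown or untested is made for them only; others in the source may bear on it.

In a physicochemical assay for permeability, using PAMPA (on this read-out higher numbers stand for higher permeability and lower numbers for lower permeability), compound 1 (`Cc1oc(-c2c(C)c(C)c(C)c(C)c2C)nc1CN1CCC(C(=O)NCCCN2C[C@H](C)C[C@H](C)C2)CC1`) gives 455 10^-6 cm/s. Compound 2 (`Cc1oc(-c2c(Cl)cccc2Br)nc1CN1CCC(C(=O)NCCCN2C[C@H](C)C[C@H](C)C2)CC1`) has the entry "not determined" (no result reported), so compound 2 stands nowhere on the numbers and offers no starting value of its own. Compound 3 (`Cc1cccc(-c2nc(CN3CCC(C(=O)NCCCN4C[C@H](C)C[C@H](C)C4)CC3)c(C)o2)c1`) is still to be measured. The change is 3-methylphenyl in place of 2-bromo-6-chlorophenyl on an aromatic carbon, next to the ring nitrogen and next to the ring oxygen. Going by the values given here, the series holds no step between measured compounds, so the data give no size for this change. Among the compounds with values here, the only reference is compound 1 at 455 10^-6 cm/s, and no step beyond the usual scatter from that value is expected in this assay, in either direction. Compound 3 is expected at 350 10^-6 cm/s, with an estimated range of 140 10^-6 cm/s to 800 10^-6 cm/s.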

Compound 3, apparent permeability: 279 10^-6 cm/s
Beside the measured number, compound 3's estimate is 1.3-fold (0.10 log units) above it, within the range that was stated.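

In this assay, going by these compounds alone, 3-methylphenyl in place of 2,3,4,5,6-pentamethylphenyl gives a 1.6-fold lower number from compound 1 to compound 3 (0.21 log units; within the scatter) as the first measured step at this position on the shared core. The two phenyl groups are therefore not told apart by this read-out, even though they differ in their number of methyl groups. The step from 2-bromo-6-chlorophenyl to 3-methylphenyl cannot be read, as compound 2 has no number, and no measurement bears on the reason for the result shown.

The compounds shown leave open whether any halogen-bearing phenyl group at this position would stay level with compound 1 and compound 3. They also leave open how a phenyl group carrying an amine or a carboxylic acid would read here.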